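The compounds below may be only part of what the source reports. "The series", "measured", "known", "first", "only" and "open" are said of these compounds alone.

Three related compounds sharing one core have been tested in a functional assay on KB cells (Homo sapiens) for inhibition, with a stated time of 72 h; a higher number here means a weaker inhibitor, a lower number a stronger inhibitor. There, compound 1 `CC(=O)O[C@@]12CO[C@@H]1C[C@H](O)[C@@](C)(C(=O)[C@H](O)C1=C(C)C3C[C@@](O)([C@H](C)OC(=O)CCC/C=C/CCCC(=O)N[C@@H](c4ccccc4)[C@@H](O)C(=O)O3)C1(C)C)C2` gives 45000 nM, the higher of the two values measured as actual numbers. The other number belongs to compound 2 `CC(=O)O[C@@]12CO[C@@H]1C[C@H](O)[C@@](C)(C(=O)[C@H](O)C1=C(C)C3C[C@@](O)([C@H](C)OC(=O)CCCC/C=C/CCCCC(=O)N[C@@H](c4ccccc4)[C@@H](O)C(=O)O3)C1(C)C)C2`, which gives 8000 nM, and the gap between the two lies beyond the usual scatter. Compound 3 `CC(=O)O[C@@]12CO[C@@H]1C[C@H](O)[C@@](C)(C(=O)[C@H](O)C1=C(C)C3C[C@@](O)([C@H](C)OC(=O)CCCCCCC(=O)N[C@@H](c4ccccc4)[C@@H](O)C(=O)O3)C1(C)C)C2` is recorded only at a limit of the assay, > 100000 nM.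

The next compound to be tested is compound 4 `CC(=O)O[C@@]12CO[C@@H]1C[C@H](O)[C@@](C)(C(=O)[C@H](O)C1=C(C)C3C[C@@](O)([C@H](C)OC(=O)CCC/C=C\CCCC(=O)N[C@@H](c4ccccc4)[C@@H](O)C(=O)O3)C1(C)C)C2`, which is a close relative of compound 1. The change is the two compounds have the same atoms and bonds; at least one stereo element is drawn with a configuration in one of them and without one in the other: 1 of 11 stereo elements differ; a double bond is drawn E in compound 1 and Z in compound 4: the two compounds have the same atoms and bonds, and a double bond is drawn E in compound 1 and Z in compound 4. Going by the values given here, no measured pair in this set isolates the geometry of a double bond, so the data give no direct guide to the effect of this change. With compound 1 at 45000 nM as the starting point, no step beyond the scatter is expected in this assay, in either direction. The expected change is a 1.1-fold lower number from compound 1 to compound 4 (0.05 log units; within the scatter). For compound 4 the estimated value is 40000 nM, with an expected range of 12000 nM to 100000 nM.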

Compound 4, half-maximal inhibitory concentration: > 100000 nM
Compound 4: a limit, no number; the forecaster's own chance of this, stated with the estimate: 25%; middle value at least 2.5-fold (0.39 log units) away from the limit.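

In this assay compound 4 is recorded only at a limit of the assay, > 100000 nM, which is not a number. Going by these compounds alone, the geometry of the double bond, which no earlier pair isolated, therefore counts at this place in the chain: going from E to Z gives an at least 2.2-fold higher number from compound 1 to compound 4 (0.34 log units; beyond the scatter). The true size of this step cannot be read, and the step stands only as a lower bound: the limit of > 100000 nM in this assay, at which 2 of the 4 values shown sit.

As far as these compounds go, it remains open whether a Z double bond in the chain of compound 2 would carry the same penalty, and how an alkyne in place of the double bond would read in this assay. The link between geometry and this result also needs care in view of how the two structures are recorded: the fact that one of compounds 1 and 4 is drawn with a defined configuration and the other without, at the place where they differ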